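This account rests on a few compounds, and the source may have more. Where it says the series, first, only, none or still open, it means among the compounds named here.

Measured so far: compound 2 `NS(=O)(=O)OC[C@@H]1C[C@@H](n2nnc3c(NCc4ccccc4F)ncnc32)C[C@@H]1O` and compound 1 `NS(=O)(=O)OC[C@@H]1C[C@@H](n2ncc3c(N[C@H]4CCc5ccccc54)ccnc32)C[C@@H]1O`.

In an assay on a protein complex for inhibition of NEDD8 activating enzyme (Homo sapiens), read by HTRF, with a stated time of 2 h, in the presence of a further agent that is not named here (a higher number here means a weaker inhibitor, a lower number a stronger inhibitor), compound 2 gives 6.11 nM. Compound 1 reaches only a limit of this assay, > 10000 nM. For the measured compounds named here, compound 2 therefore stands as the single numeric value in the pair, the other being (the limit of > 10000 nM in this assay, at which 1 of the 2 values shown sits). Compound 3 `NS(=O)(=O)OC[C@@H]1C[C@@H](n2nnc3c(NCc4cccs4)ncnc32)C[C@@H]1O` carries thiophen-2-yl in place of 2-fluorophenyl on a saturated chain carbon bound to a nitrogen on an aromatic ring. Going by the values given here, no step between two measured compounds is available to scale this exchange. The shift in this assay is expected to stay within the usual scatter, with the step from compound 2 to compound 3 estimated at a 1.3-fold higher number from compound 2 to compound 3 (0.12 log units; within the scatter). Compound 3 is estimated at 8 nM, range 3 nM to 25 nM.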

Compound 3, half-maximal inhibitory concentration: 15.9 nM
The estimate for compound 3 lay 2.0-fold (0.30 log units) below the measured number, and the stated range covers the measured number.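

In this assay, thiophen-2-yl in place of 2-fluorophenyl on a saturated chain carbon bound to a nitrogen on an aromatic ring gives a 2.6-fold higher number from compound 2 to compound 3 (0.42 log units; beyond the scatter). For the compounds shown here, this is the only step that scales this place, and it shows that a five-membered aromatic ring with 1 hetero atom keeps the inhibitor strong, with compound 3 at 15.9 nM, though the step is modest. Nothing given here accounts for its size.

Still open, going by these compounds, is how a non-aromatic ring at this place, such as cyclohexyl, would read. Also open, on these data alone, is whether a furan-2-yl or pyridin-2-yl ring would behave like thiophen-2-yl.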